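The source may hold more compounds than are shown below. What is called first, only, known or untested is meant among the compounds shown, and "the series" means these compounds.

For the measured compounds named here, in an ADME assay on Vero 76 cells (Chlorocebus sabaeus) for cytotoxicity, read by MTT assay, with a stated time of 96 h (a lower number here means that less compound is tolerated, a higher number that more compound is tolerated), compound 1 (`Cc1ccc(NCc2cn(-c3ccccc3)nc2-c2ccc(C(F)(F)F)cc2)cc1`) gives 82000 nM as the only actual number among the three compounds measured. Compound 2 (`Cc1ccc(NCc2cn(-c3ccccc3)nc2-c2ccc(C)cc2)cc1`) reads > 100000 nM and this is a limit of the assay. Compound 3 (`Cc1ccc(NCc2cn(-c3ccccc3)nc2-c2ccccc2)cc1`) reads > 100000 nM and this too is a limit. The series therefore rests on one number and on the limit of > 100000 nM in this assay, at which 2 of the 3 values shown sit, as its other reference point. Methyl in place of trifluoromethyl gives an at least 1.2-fold higher number from compound 1 to compound 2 (0.08 log units; that floor lies within the scatter) and hydrogen in place of trifluoromethyl gives an at least 1.2-fold higher number from compound 1 to compound 3 (0.08 log units; that floor lies within the scatter) while hydrogen in place of methyl gives a step that the two limits leave unreadable from compound 2 to compound 3 on that same carbon.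

Compound 4 (`FC(F)(F)c1ccc(-c2nn(-c3ccccc3)cc2CNc2ccc(Br)cc2)cc1`) keeps the trifluoromethyl and changes elsewhere: bromo in place of methyl on an aromatic carbon describes bromo in place of methyl on an aromatic carbon, para to a large group. Going by the values given here, no measured step touches that place, so the expectation stays close to compound 1 at 82000 nM and no step beyond the scatter is expected in this assay for this change. The expected step is a 1.4-fold lower number from compound 1 to compound 4 (0.14 log units; within the scatter) as an estimate only. Compound 4 is estimated at 60000 nM with an expected range from 25000 nM to 100000 nM as its bounds.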

Compound 4, half-maximal cytotoxic concentration: 17000 nM
For compound 4 the middle estimate is 3.5-fold (0.55 log units) above the measured one; the whole stated range lies above it.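

In this assay, bromo in place of methyl on an aromatic carbon, para to a large group, gives a 4.8-fold lower number from compound 1 to compound 4 (0.68 log units; beyond the scatter). For the compounds shown here, this is the first change with a size that stands beyond the scatter: the earlier steps, all at the other ring carbon that carries trifluoromethyl, have floors within the scatter or cannot be read, and this one shows that the change from (4-methylphenyl)amino to (4-bromophenyl)amino does move the number with the trifluoromethyl kept. Only compound 1 and compound 4 give actual numbers, and the rest of the series rests on a limit: the limit of > 100000 nM in this assay, at which 2 of the 4 values shown sit.

The compounds shown leave open how a chloro group, a methoxy group or an amine on that same carbon would read. They also leave open whether bromo would give a step of this size in compound 2 or compound 3.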